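The source may hold more compounds than are shown below. What is called first, only, known or untested is meant among the compounds shown, and "the series" means these compounds.

Measured so far, with their readings in a functional assay on CEM-CCRF cells for antagonist activity at C-X-C chemokine receptor type 4 (Homo sapiens), read by calcium flux; on this read-out higher numbers stand for weaker inhibition and lower numbers for stronger inhibition:

Compound 1, `NCc1ccccc1CN(Cc1nc2ccccc2[nH]1)C1CCCc2cccnc21`: 28 nM
Compound 2, `NCc1cc(F)ccc1CN(Cc1nc2ccccc2[nH]1)C1CCCc2cccnc21`: 219 nM
Compound 3, `NCc1cc(C(F)(F)F)ccc1CN(Cc1nc2ccccc2[nH]1)C1CCCc2cccnc21`: 51 nM

All three share one core and differ only in a single group on the benzene ring that carries the aminomethyl. Compound 3 stands second highest of the three: against compound 1 it shows a 1.8-fold higher number from compound 1 to compound 3 (0.26 log units; within the scatter), and against compound 2 it shows a 4.3-fold lower number from compound 2 to compound 3 (0.63 log units; beyond the scatter). Compound 2 itself lies furthest from compound 1, with a 7.8-fold higher number from compound 1 to compound 2 (0.89 log units; beyond the scatter).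

Compound 4, `NCc1ccc(CN(Cc2nc3ccccc3[nH]2)C2CCCc3cccnc32)c(CN)c1`, is the next step: aminomethyl in place of trifluoromethyl on an aromatic carbon. Within the data shown here, no measured step here exchanges a trifluoromethyl for an aminomethyl, so the comparison rests on how little the ring substituent has mattered between compound 1 and compound 3, against the modest loss seen with compound 2. Compound 4 is therefore expected to land near compound 3, at about 65 nM, within a range of 15 nM to 280 nM. That estimate amounts to an expected 1.3-fold higher number from compound 3 to compound 4 (0.11 log units; within the scatter), no more than the scatter.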

Compound 4, half-maximal inhibitory concentration: 10 nM
The estimate for compound 4 lay 6.5-fold (0.81 log units) above the measured number; the measured number lies below the stated range.
By their numbers in this assay, from the lowest: compound 4; then compounds 1 and 3 (each within the scatter of the next); then compound 2.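

In this assay, aminomethyl is the only group at this position among those shown that clearly improves on plain hydrogen, with a 2.8-fold lower number from compound 1 to compound 4 (0.45 log units; beyond the scatter); fluoro raised the number, and trifluoromethyl stayed within the scatter of hydrogen. Putting aminomethyl in place of the other two groups shows how much the choice of group matters here, with a 5.1-fold lower number from compound 3 to compound 4 (0.71 log units; beyond the scatter) and, the largest of these steps, a 22-fold lower number from compound 2 to compound 4 (1.34 log units; beyond the scatter). Aminomethyl counts a hydrogen-bond donor and acceptor that trifluoromethyl lacks, but nothing available says whether that difference matters for this result.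

The compounds shown leave open whether the nitrogen of the aminomethyl is needed, which a hydroxymethyl or methyl group at this position would test. They also leave open how a longer aminoethyl chain or a carboxylic acid would fare there.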